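Diaryl series: hydroxymethyl in place of methoxymethyl

The compounds below may be only part of what the source reports. "The series", "measured", "known", "first", "only" and "open" are said of these compounds alone.

Working notes on a small set of diaryl compounds, all tested in a functional assay on HeLa cells (Homo sapiens) for cytotoxicity, read by WST assay, with a stated time of 48 h; on this read-out lower numbers stand for stronger inhibition and higher numbers for weaker inhibition. Compound 1 `COC[C@@H](C)[C@H](C)C(c1ccc(O)c(OC)c1)c1ccc(O)c(OC)c1` is the compound with the lowest number shown in this assay; it gives 58000 nM. Compound 2 `COc1ccc(C(c2ccc(OC)c(OC)c2)[C@H](C)[C@@H](C)CO)cc1OC` gives 67000 nM in this assay; the two numbers stand within the scatter of each other, so no order between compound 1 and compound 2 can be read from them. Compound 2 also differs from compound 1 at more than one place, so it offers no single-point comparison.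

Compound 3 `COc1cc(C(c2ccc(O)c(OC)c2)[C@H](C)[C@@H](C)CO)ccc1O` has not yet been measured. It differs from compound 1 as follows: 2-(hydroxymethyl)-1-methylpropyl in place of 2-(methoxymethyl)-1-methylpropyl on a saturated chain carbon bound to two aromatic carbons. Within the data shown here, no measured pair shows the effect of this change on its own, so the expectation rests on the position of compound 1 alone. The step from compound 1 to compound 3 is expected to be small, no larger than the scatter, in either direction: a 1.0-fold higher number from compound 1 to compound 3 (0.01 log units; within the scatter). Compound 3 is therefore expected to give about 60000 nM in this assay, within a range from 25000 nM to 150000 nM.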

Compound 3, half-maximal inhibitory concentration: > 100000 nM
Compound 3: no number, only a limit; the forecaster's own chance of this, stated with the estimate: 10%; middle value at least 1.6-fold (0.22 log units) from the limit.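

Among these compounds, this is the first single-point comparison: on a saturated chain carbon bound to two aromatic carbons, 2-(hydroxymethyl)-1-methylpropyl in place of 2-(methoxymethyl)-1-methylpropyl gives, in this assay, an at least 1.7-fold higher number from compound 1 to compound 3 (0.23 log units; that floor lies within the scatter). Compound 3 gives only a limit, > 100000 nM, so the step is a floor and not a size. The change brings no lower number in this assay, and its true size stays unread, as the reading rests on a limit: the limit of > 100000 nM in this assay, at which 1 of the 3 values shown sits.

Open, from the compounds shown here alone, is how an amine, a carboxylic acid or a longer chain would read in this assay in place of 2-(methoxymethyl)-1-methylpropyl. Among the compounds shown here, also open is whether this step would hold on the core of compound 2, since no step involving compound 2 can be read.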